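The source may hold more compounds than are shown below. What is called first, only, known or untested is meant among the compounds shown, and "the series" means these compounds.

Measured compounds in this set:
- compound 1, `COc1ccc(N2C(=O)COc3ccc(-c4cnc(OC)c(NS(=O)(=O)c5ccc(F)cc5)c4)cc32)cc1`: 1220 nM
- compound 2, `O=C1COc2ccc(-c3cnc(Cl)c(NS(=O)(=O)c4ccc(F)cc4)c3)cc2N1c1ccccc1`: 10300 nM
- compound 3, `COc1cccc(N2C(=O)COc3ccc(-c4ccc(O)cc4)cc32)c1`: a limit of the assay, > 40000 nM

The read-out is a functional assay on HeLa cells (Homo sapiens) for antiproliferative activity, read by MTT assay, with a stated time of 72 h; a lower number here means a stronger inhibitor, a higher number a weaker inhibitor. Among the two numbers in hand, compound 1 holds the lower; compound 2 sits higher, and the gap between them is beyond the scatter of repeated runs. For compound 3 only a limit is reported, (the limit of > 40000 nM in this assay, at which 1 of the 3 values shown sits), so it gives no number against which to rank.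

The unmeasured compound 4 is `COc1ncc(-c2ccc3c(c2)N(C2CCCCC2)C(=O)CO3)cc1NS(=O)(=O)c1ccc(F)cc1`. It differs from compound 1 in one place: cyclohexyl in place of 4-methoxyphenyl on an amide-type nitrogen in a ring. Going by the values given here, no step between two measured compounds covers this kind of change, so no measured precedent sets its size. The rest of the molecule is kept as in compound 1, including the substituted pyridine with its sulfonamide, which compound 2 shows to be sensitive to its own substitution.

The expectation is a moderate weakening, a step of a 2.0-fold higher number from compound 1 to compound 4 (0.31 log units; beyond the scatter) that may fall close to the edge of the scatter rather than far beyond it. Compound 4 is accordingly estimated at 2500 nM, with a range from 800 nM to 8000 nM.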

Compound 4, half-maximal inhibitory concentration: 6100 nM
Compound 4: middle estimate off by 2.4-fold (0.39 log units), on the low side, and the stated range covers the measured number.
By their numbers in this assay, from the lowest: compound 1; then compounds 4 and 2 (each within the scatter of the next). At a limit, above all of these: compound 3.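

In this assay, going by these compounds alone, the amide-type nitrogen in a ring now has its first comparison in which only this substituent changes: cyclohexyl in place of 4-methoxyphenyl gives a 5.0-fold higher number from compound 1 to compound 4 (0.70 log units; beyond the scatter). The change is modest, so a measurable antiproliferative number remains after an aromatic ring is exchanged for a non-aromatic ring of carbon only, but this position is not indifferent to the exchange, and 4-methoxyphenyl gives the lower number of the pair. Nothing in hand gives a cause for this step.

This single pair cannot separate the loss of the aromatic ring from the loss of the methoxy group, and a plain phenyl on this nitrogen, with the rest of compound 1 kept, would divide the step between the two. Also open, from the compounds shown here alone, is how far the position extends to other kinds of group, such as a short chain like ethyl, a chain ending in an amine, or a carboxylic acid, and whether the step keeps its size when the rest of the molecule differs from compound 1.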